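Isopropoxy in Place of Fluorophenyl on a Flat Series

The compounds below may be only part of what the source reports. "The series", "measured", "known", "first", "only" and "open" are said of these compounds alone.

Compound 1 `Cc1ccccc1-c1cc(C(=O)N2CCC3(CC2)CC(=O)c2nn(C(C)(C)C)cc2O3)c2ccccc2n1`: > 10000 nM
Compound 2 `CC(C)(C)n1cc2c(n1)C(=O)CC1(CCN(C(=O)c3cc(-c4ccc(F)cc4)nc4ccccc34)CC1)O2`: > 10000 nM
Compound 3 `CCOc1cc(C(=O)N2CCC3(CC2)CC(=O)c2nn(C(C)(C)C)cc2O3)c2ccccc2n1`: > 10000 nM

In a functional assay on MDA-MB-231 cells (Homo sapiens) for inhibition, read by MTT assay, with a stated time of 72 h (a lower number here means a stronger inhibitor, a higher number a weaker inhibitor), compound 2 gives only a limit, > 10000 nM, and not a number. The same holds for its two neighbours, so that the steps a step that the two limits leave unreadable from compound 1 to compound 2, a step that the two limits leave unreadable from compound 1 to compound 3 and a step that the two limits leave unreadable from compound 2 to compound 3 cannot be read; every value here sits at the limit of > 10000 nM in this assay, at which 3 of the 3 values shown sit. Compound 4 `CC(C)Oc1cc(C(=O)N2CCC3(CC2)CC(=O)c2nn(C(C)(C)C)cc2O3)c2ccccc2n1` differs from compound 2 by isopropoxy in place of 4-fluorophenyl on an aromatic carbon. Compound 3, the ethoxy analogue, likewise returns only a limit, > 10000 nM. With no readable step in the set, compound 4 is expected to give 15000 nM, with a range of 7000 nM to 50000 nM, most probably again as a limit. The step that the limit leaves unreadable from compound 2 to compound 4 is expected to be no change beyond the scatter.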

Compound 4, half-maximal inhibitory concentration: > 10000 nM
Compound 4: only a limit was reported; the forecaster's own chance of this, stated with the estimate: 85%; the middle value lies beyond the limit too.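

Compound 4 also gives only a limit, > 10000 nM. The steps linking compound 1, compound 2 and compound 3 to compound 4 therefore cannot be read: the limit of > 10000 nM in this assay, at which 4 of the 4 values shown sit.

These compounds leave open how any of these groups ranks in this assay, since none gives a number.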